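One Ring Grows: From Compound 2 to Compound 3

The source may report more compounds than this note shows. Statements on the series, on what has been measured and on what is new or still open speak of the compounds shown alone.

Of the compounds shown here, two from this series have been measured in an assay on CCRF-CEM cells for displacement of a labelled ligand from C-X-C chemokine receptor type 4 (Homo sapiens); a lower number here means a stronger inhibitor, a higher number a weaker inhibitor. Compound 1 `CN(/C(=N/C1CCCCC1)SCC1=CSC2=NCCN12)C1CCCCC1` gives 3580 nM. Compound 2 `C1=C(CS/C(=N\C2CCCC2)NC2CCCC2)N2CCN=C2S1` gives 3840 nM. The gap between compound 2 and compound 1 lies within the usual scatter of repeated measurements, so the two cannot be told apart in this assay. Compound 3 `C1=C(CS/C(=N\C2CCCCC2)NC2CCCC2)N2CCN=C2S1` has not yet been measured. It differs from compound 2 by cyclohexyl in place of cyclopentyl on a double-bonded nitrogen. For the measured compounds named here, no measured pair in this set isolates that change. Compound 1 carries two cyclohexyl groups and compound 2 two cyclopentyl groups, and because compound 1 with 3580 nM and compound 2 with 3840 nM do not separate, no step beyond the scatter is expected in this assay in either direction. The step from compound 2 to compound 3 is estimated at a 1.0-fold lower number from compound 2 to compound 3 (0.02 log units; within the scatter). Compound 3 is expected to give 3700 nM, within a range from 1800 nM to 7500 nM.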

Compound 3, half-maximal inhibitory concentration: 372 nM
The estimate for compound 3 lay 9.9-fold (1.00 log units) above the measured number; the whole stated range lies above it.
By their numbers in this assay, from the lowest: compound 3; then compounds 1 and 2 (each within the scatter of the next).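

In this assay, the group on the double-bonded nitrogen proves decisive: cyclohexyl in place of cyclopentyl there gives a 10-fold lower number from compound 2 to compound 3 (1.01 log units; beyond the scatter), a difference that the two earlier compounds, which could not be told apart, gave no sign of. Compound 3 also separates from compound 1, with cyclopentylamino in place of cyclohexyl(methyl)amino on a carbon with a double bond to nitrogen giving a 9.6-fold lower number from compound 1 to compound 3 (0.98 log units; beyond the scatter), so cyclohexyl on the double-bonded nitrogen does not suffice alone in this small set. Nothing at hand explains why this pairing of rings stands apart.

The compounds shown leave open whether the methyl group or the ring size on the amino side accounts for the gap to compound 1. They also leave open how cycloheptyl or phenyl on the double-bonded nitrogen would compare.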